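This account rests on a few compounds, and the source may have more. Where it says the series, first, only, none or still open, it means among the compounds named here.

In a functional assay (Cavia porcellus) for inhibition of cysteinyl leukotriene receptor (Homo sapiens) (a lower number here means a stronger inhibitor, a higher number a weaker inhibitor), compound 3 `O=C(CCCOc1ccc(OCc2ccc3ccccc3n2)cc1)NS(=O)(=O)c1ccccc1` gives 19 nM, the lowest of the three numbers measured: compound 2 `c1ccc2nc(COc3ccc(OCCCc4nnn[nH]4)cc3)ccc2c1` gives 250 nM and compound 1 `c1ccc2nc(COc3ccc(Cc4nnn[nH]4)cc3)ccc2c1` gives 1000 nM. Compound 4 `O=C(O)CCCOc1ccc(OCc2ccc3ccccc3n2)cc1` keeps the shared core of compound 3 but carries hydroxy in place of (phenylsulfonyl)amino on a carbonyl carbon. For the measured compounds named here, no measured step touches this position; the only step recorded, a 4.0-fold lower number from compound 1 to compound 2 (0.60 log units; beyond the scatter), alters a different group on the aromatic ring, so it offers no direct guide. What the numbers do show is that both compounds without the (phenylsulfonyl)amino group sit well behind compound 3. Compound 4 is therefore expected to lose a good deal of potency, estimated as an 11-fold higher number from compound 3 to compound 4 (1.02 log units; beyond the scatter), landing near 200 nM with a likely range from 60 nM to 700 nM.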

Compound 4, half-maximal inhibitory concentration: 800 nM
Compound 4: middle estimate off by 4.0-fold (0.60 log units), on the low side; the measured number lies above the stated range.
By their numbers in this assay, from the lowest: compound 3; then compound 2; then compounds 4 and 1 (each within the scatter of the next).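

In this assay, the (phenylsulfonyl)amino group on this carbonyl carbon matters greatly: hydroxy in its place gives a 42-fold higher number from compound 3 to compound 4 (1.62 log units; beyond the scatter). The remaining carboxy compound gives a 3.2-fold higher number from compound 2 to compound 4 (0.51 log units; beyond the scatter), a modest step against the tetrazole on the same chain, while a 1.3-fold lower number from compound 1 to compound 4 (0.10 log units; within the scatter) is a difference within the scatter. Nothing measured here explains why the (phenylsulfonyl)amino group has such a large effect. Going by these compounds, it remains open whether the benzene ring of that group is needed, which a methylsulfonylamino group on the same carbonyl carbon would test. A longer chain carrying the (phenylsulfonyl)amino group is also an open case.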